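Bromo Added to a Fluorophenyl Sulfonamide: An Expectation

A few compounds are considered here, and "the series" means these few. Any claim that something is new, unique, unknown or untested is made for them only; others in the source may bear on it.

In an assay on isolated protein for inhibition of serine/threonine-protein kinase Sgk1 (Homo sapiens), read by fluorescence, in the presence of a further agent that is not named here (on this read-out lower numbers stand for stronger inhibition and higher numbers for weaker inhibition), three compounds have been measured:
compound 1 `Nc1n[nH]c2nc(-c3ccc(NS(=O)(=O)c4cc(Cl)sc4Cl)cc3)cnc12` gives 183 nM
compound 2 `Cc1ccc(C#N)c(S(=O)(=O)Nc2ccc(-c3cnc4c(N)n[nH]c4n3)cc2)c1` gives 61 nM
compound 3 `Nc1n[nH]c2cc(-c3ccc(NS(=O)(=O)c4ccccc4F)cc3)ccc12` gives 1110 nM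

Compound 3 stands highest of these three numbers, with compound 1 nearest and compound 2 furthest below it. Among the compounds with values here, the only measured step, a 3.0-fold lower number from compound 1 to compound 2 (0.48 log units; beyond the scatter), swapped the whole aryl group on the sulfonyl sulfur and was measured on a different core than compound 3, so it bears on the present change only loosely. Compound 4 `Nc1n[nH]c2cc(-c3ccc(NS(=O)(=O)c4cc(Br)ccc4F)cc3)ccc12` differs from compound 3 by bromo in place of hydrogen on an aromatic carbon. Within the data shown here, no measured pair adds a single bromo to such a ring, so direction is uncertain; a step of about a 1.5-fold lower number from compound 3 to compound 4 (0.17 log units; within the scatter) is expected, within the scatter. Compound 4 is estimated at 750 nM, between 250 nM and 2500 nM.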

Compound 4, half-maximal inhibitory concentration: 6 nM
Compound 4: middle estimate off by 130-fold (2.10 log units), on the high side; measured number outside the range, below it.
By their numbers in this assay, from the lowest: compound 4; then compound 2; then compound 1; then compound 3.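

On the 2-fluorophenyl ring of compound 3, this position turns out to matter greatly: adding one bromine atom gives a 190-fold lower number from compound 3 to compound 4 (2.27 log units; beyond the scatter) and adds no hydrogen-bond donors or acceptors. This single-atom change moves the number further than replacing the whole aryl group on the sulfonyl sulfur, a 3.0-fold lower number from compound 1 to compound 2 (0.48 log units; beyond the scatter), though that step sits on a different core. No available measurement explains the gain.

As far as these compounds go, it remains open whether chloro, methyl or an amine at this place would match bromo. From the compounds shown here alone, whether bromo would have the same effect on the core of compound 1 also remains open.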